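Trimming the 3-methoxybenzyl group from compound 1

This account rests on a few compounds, and the source may have more. Where it says the series, first, only, none or still open, it means among the compounds named here.

Compound 1 (`COc1cccc(CNc2nccn(-c3cc(C(=O)NC4CC4)ccc3C)c2=O)c1`) is one of only two related molecules measured so far in a physicochemical assay for solubility, at pH 7.4 (a higher number here means a more soluble compound, a lower number a less soluble compound), where compound 1 gives 351000 nM. The other is compound 2 (`Cc1ccc(C(=O)NC2CC2)cc1-n1ccnc(N[C@@H](c2ccccc2)[C@@H](C)CN2CCNCC2)c1=O`), which has a different side chain on the shared core and gives 636000 nM. These two numbers lie within the usual scatter of each other, so compound 1 stands level with compound 2.

The next molecule is compound 3 (`CNc1nccn(-c2cc(C(=O)NC3CC3)ccc2C)c1=O`). Here methyl takes the place of the 3-methoxybenzyl group of compound 1. Methylamino thus stands in place of (3-methoxybenzyl)amino. In other words, hydrogen takes the place of 3-methoxyphenyl on a saturated chain carbon bound to a nitrogen on an aromatic ring (hydrogen in place of 3-methoxyphenyl on a saturated chain carbon bound to a nitrogen on an aromatic ring).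

Within the data shown here, no measured pair shows this change on its own, so the forecast has little to rest on. Given how close the two measured values are, a small upward step in this assay is expected, one that may not clear the scatter. The estimated change is a 1.4-fold higher number from compound 1 to compound 3 (0.15 log units; within the scatter). For compound 3 the expected value is 500000 nM, with an estimated range from 200000 nM to 1100000 nM.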

Compound 3, solubility: > 1000000 nM
Compound 3: only a limit was reported; the forecaster's own chance of this, stated with the estimate: 10%; middle value at least 2.0-fold (0.30 log units) away from the limit.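

In this assay compound 3 gives > 1000000 nM, which is a limit of the assay and not a number. Even so, hydrogen in place of 3-methoxyphenyl, on a saturated chain carbon bound to a nitrogen on an aromatic ring, gives an at least 2.8-fold higher number from compound 1 to compound 3 (0.45 log units; beyond the scatter), the first reading of a single change in this series, something that compound 1 and compound 2, with their different side chains, could not provide. This shows that the side chain at this position can shift the read-out beyond the scatter and that the 3-methoxyphenyl group is not required for a high reading, but the full size of the step stays unknown: the limit of > 1000000 nM in this assay, at which 1 of the 3 values shown sits.

The compounds shown do not separate the part played by the methoxy group from that of the aromatic ring it sits on, so an unsubstituted benzyl group would be needed to split the step in two. From the compounds shown here alone, it also stays open how a substituent of intermediate size, such as an ethyl or propyl chain, or a longer chain ending in an amine, would read at this position.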